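A few compounds are considered here, and "the series" means these few. Any claim that something is new, unique, unknown or untested is made for them only; others in the source may bear on it.

Of the compounds shown here, three have been tested in a functional assay on PC-3 cells (Homo sapiens) for inhibition, read by sulforhodamine B assay, with a stated time of 48 h, tested at 50 uM (on this read-out lower numbers stand for less inhibition of growth and higher numbers for more inhibition of growth at the one concentration tested), so far, and they share one core while differing in what hangs from the oxime position. Compound 1 `COc1ccc([C@@H]2C/C(=N/OCc3cn(-c4ccc(Cl)cc4C)nn3)c3cc(CC=C(C)C)c(OC)cc3O2)cc1` carries a triazole linked through an oxygen to that position, and in this assay compound 1 gives 49%. Compound 2 `COc1ccc([C@@H]2CC(=O)c3cc(CC=C(C)C)c(OC)cc3O2)cc1` keeps a plain carbonyl at that position, and in this assay compound 2 gives 58%. Compound 3 `COc1ccc([C@@H]2C/C(=N/O)c3cc(CC=C(C)C)c(OC)cc3O2)cc1` bears a free oxime, and in this assay compound 3 gives 45%. The number for compound 1 sits between the other two, and both gaps lie within the usual scatter of this kind of measurement, so the three compounds cannot be told apart on these data.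

Compound 4 `COc1ccc([C@@H]2C/C(=N/OCc3cn(-c4ccc(NC(C)=O)cc4)nn3)c3cc(CC=C(C)C)c(OC)cc3O2)cc1` is the next compound to be measured. It differs from compound 1 in one place: 4-acetamidophenyl in place of 4-chloro-2-methylphenyl on an aromatic nitrogen. Going by the values given here, no measured pair shows what such a swap does here, so there is no step to lean on. Because compound 1 gives 49% and the other two values fall in the same narrow band, a step of no more than the scatter, in either direction, is expected from compound 1 to compound 4 in this assay, that is a number 1 percentage points lower from compound 1 to compound 4 (within the scatter). Compound 4 is therefore estimated at 48% in this assay, with a range from 32% to 64%.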

Compound 4, percent growth inhibition at one concentration: 2%
Estimate against measurement, compound 4: 46 percentage points above, outside the stated range (below it).
By their numbers in this assay, from the lowest: compound 4; then compounds 3, 1 and 2 (each within the scatter of the next, the first and the last beyond it).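

In this assay, 4-acetamidophenyl in place of 4-chloro-2-methylphenyl on the aromatic nitrogen of the triazole gives a number 47 percentage points lower from compound 1 to compound 4 (beyond the scatter). Going by these compounds alone, the earlier compounds could not be told apart, so this is the first sign that the group at this position can largely decide whether growth is inhibited at the one concentration tested. By count, the entering group brings a hydrogen-bond donor and a hydrogen-bond acceptor where the leaving group has neither, but nothing measured here explains the step.

Going by these compounds, this single swap removes the chlorine and the methyl and adds the acetamide all at once, so it remains open which of these changes matters. Compounds with a plain phenyl, or with an amine or a carboxylic acid on that phenyl ring, would help to separate these changes.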